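Swapping pyridine for pyrazine on an imidazoline aryl amine

The compounds below may be only part of what the source reports. "The series", "measured", "known", "first", "only" and "open" are said of these compounds alone.

Among the compounds with values here, compound 2 `c1ccc(-c2ccccc2NCC2=NCCN2)nc1` gives 41.7 nM in a functional assay for activation of Alpha-1D adrenergic receptor (Homo sapiens) (a higher number here means that more compound is needed for the effect, a lower number that less compound is needed), the only plain number among the measurements so far. Compound 1 `Cc1nc(-c2ccccc2NCC2=NCCN2)no1` reaches only a limit, < 5020 nM. The step that the limit leaves unreadable from compound 1 to compound 2 therefore cannot be read, due to the limit of < 5020 nM in this assay, at which 1 of the 2 values shown sits. Compound 3 `c1ccc(-c2cnccn2)c(NCC2=NCCN2)c1` carries the change (pyrazin-2-yl in place of pyridin-2-yl on an aromatic carbon). Within the data shown here, no measured step bears on this change, so the expectation rests on compound 2 alone; only a small shift, near the usual scatter, is expected. Compound 3 is estimated at 80 nM, between 20 nM and 400 nM, an expected step of a 1.9-fold higher number from compound 2 to compound 3 (0.28 log units; within the scatter).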

Compound 3, half-maximal effective concentration: 182 nM
Estimate against measurement, compound 3: 2.3-fold (0.36 log units) below, within the range that was stated.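

Replacing one ring carbon of the pyridin-2-yl group with nitrogen gives a 4.4-fold higher number from compound 2 to compound 3 (0.64 log units; beyond the scatter) in this assay, so this position responds to a change that leaves the ring size and heavy-atom count as they were. Compound 1 gives only a limit, and its steps to compound 2 and compound 3 cannot be read: the limit of < 5020 nM in this assay, at which 1 of the 3 values shown sits.

Going by these compounds, it remains open how a plain phenyl ring, with no ring nitrogen, would compare at this position. A pyridin-3-yl group would show whether the place of the ring nitrogen matters.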